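The compounds below may be only part of what the source reports. "The series", "measured", "known", "first", "only" and "open" are said of these compounds alone.

Measured compounds in an assay on HEK-293T cells for displacement of a labelled ligand from transmembrane domain-containing protein TMIGD3 (Homo sapiens), read by scintillation counting and radioligand binding, with stated times of 10 min and 90 min; a higher number here means a weaker inhibitor, a lower number a stronger inhibitor:
compound 1, `CCOC(=O)[C@@]12C[C@@H]1[C@@H](n1cnc3c(NC)nc(C#Cc4ccc(Cl)s4)cc31)[C@H](O)[C@@H]2O`, gives 169 nM
compound 2, `CCCOC(=O)[C@@]12C[C@@H]1[C@@H](n1cnc3c(NC)nc(C#Cc4ccc(Cl)s4)nc31)[C@H](O)[C@@H]2O`, gives 5.78 nM
compound 3, `CCCCOC(=O)[C@@]12C[C@@H]1[C@@H](n1cnc3c(NC)nc(C#Cc4ccc(Cl)s4)nc31)[C@H](O)[C@@H]2O`, gives 17.5 nM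

Among these three numbers compound 3 stands second highest: compound 2 sits below it by the step of a 3.0-fold higher number from compound 2 to compound 3 (0.48 log units; beyond the scatter), and compound 1 lies well above it, although compound 1 also carries a different core and no single step links the two.

Compound 4, `CNc1nc(C#Cc2ccc(Cl)s2)nc2c1ncn2[C@H]1[C@H](O)[C@H](O)[C@]2(C(=O)OCc3ccccc3)C[C@H]12`, is the next one to be measured. It differs from compound 3 in one place: phenyl in place of propyl on a saturated chain carbon bound to an oxygen next to a carbonyl group. Among the measured compounds shown here, only one measured step touches the same ester chain, the step of a 3.0-fold higher number from compound 2 to compound 3 (0.48 log units; beyond the scatter), where adding a single methyl to the chain already gave a modestly higher number. For the measured compounds named here, a phenyl is a larger addition than that methyl, so a further rise would not be surprising, yet nothing among the measured compounds shows what an aromatic ring does at this position, and the direction remains uncertain.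

On balance compound 4 is expected to come out near or somewhat above compound 3, with the estimated step of a 1.4-fold higher number from compound 3 to compound 4 (0.15 log units; within the scatter). The estimate for compound 4 in this assay is 25 nM, with a range from 8 nM to 80 nM.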

Compound 4, inhibition constant: 7.31 nM
Estimate against measurement, compound 4: 3.4-fold (0.53 log units) above; the measured number lies below the stated range.
By their numbers in this assay, from the lowest: compounds 2 and 4 (each within the scatter of the next); then compound 3; then compound 1.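

In this assay the number at this ester chain does not simply rise as the chain grows: the change from butoxycarbonyl to benzyloxycarbonyl, which brings in phenyl with 6 heavy atoms where propyl had 3, gives a 2.4-fold lower number from compound 3 to compound 4 (0.38 log units; beyond the scatter) and so runs the opposite way to a 3.0-fold higher number from compound 2 to compound 3 (0.48 log units; beyond the scatter) where a single methyl was added. Set against the shorter ester, the change gives a 1.3-fold higher number from compound 2 to compound 4 (0.10 log units; within the scatter) and so compound 2 and compound 4 cannot be told apart here. An aromatic ring on the saturated chain carbon bound to an oxygen next to a carbonyl group is therefore compatible with a number as low as any among these esters, so the count of heavy atoms alone does not predict the result across compound 2, compound 3 and compound 4.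

Nothing available explains why the phenyl compound differs from the butyl compound. Still open, from the compounds shown here alone, is how a longer chain such as hexyl, a chlorine on the phenyl ring, a pyridine ring in place of phenyl, or a carboxylic acid or amide in place of the ester would read in this assay on the shared core.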